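The source may hold more compounds than are shown below. What is called first, only, known or untested is meant among the compounds shown, and "the series" means these compounds.

In a functional assay on SW 1116 cells (Homo sapiens) for cytotoxicity, read by MTT assay, with a stated time of 48 h (on this read-out lower numbers stand for stronger inhibition and higher numbers for weaker inhibition), compound 1 `O=C(CSc1nnc(-c2ccncc2)o1)N/N=C/c1ccc([N+](=O)[O-])cc1` gives 25800 nM, compound 2 `O=C(CSc1nnc(-c2ccncc2)o1)N/N=C/c1ccc(O)cc1` gives 12200 nM, and compound 3 `COc1ccc(/C=N/NC(=O)CSc2nnc(-c3ccncc3)o2)cc1` gives 20300 nM. Compound 3 thus lies within the scatter of both other compounds. Compound 4 `COc1cccc(/C=N/NC(=O)CSc2nnc(-c3ccncc3)o2)c1` has the same atoms as compound 3, joined differently: 3-methoxyphenyl in place of 4-methoxyphenyl on a carbon with a double bond to nitrogen. Among the compounds with values here, no measured step shows such a shift of the methoxy group, so the evidence is indirect. Exchanging the group itself produced only small steps: a 2.1-fold lower number from compound 1 to compound 2 (0.33 log units; beyond the scatter), a 1.3-fold lower number from compound 1 to compound 3 (0.10 log units; within the scatter), and a 1.7-fold higher number from compound 2 to compound 3 (0.22 log units; within the scatter). On these steps, no change beyond the scatter is expected in this assay, and the estimated step is a 1.0-fold lower number from compound 3 to compound 4 (0.01 log units; within the scatter). Compound 4 is expected at 20000 nM, with an estimated range of 9000 nM to 42000 nM.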

Compound 4, half-maximal inhibitory concentration: 16500 nM
Estimate against measurement, compound 4: 1.2-fold (0.08 log units) above; measured number inside the range.
By their numbers in this assay, from the lowest: compounds 2, 4, 3 and 1 (each within the scatter of the next, the first and the last beyond it).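

In this assay, within the data shown here, 3-methoxyphenyl in place of 4-methoxyphenyl on a carbon with a double bond to nitrogen gives the first direct reading of this shift, a 1.2-fold lower number from compound 3 to compound 4 (0.09 log units; within the scatter) and so no difference between the two placements. Compound 4 also stays within the scatter of the hydroxy and nitro compounds, with a 1.4-fold higher number from compound 2 to compound 4 (0.13 log units; within the scatter) and a 1.6-fold lower number from compound 1 to compound 4 (0.19 log units; within the scatter) as the printed steps. No measurement offers an explanation for these small steps. From the compounds shown here alone, whether an amine, a carboxylic acid or a longer chain in place of methoxy would move the number beyond the scatter remains open.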